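The compounds below may be only part of what the source reports. "The series", "measured", "known", "first", "only" and "open" are said of these compounds alone.

Compound 1 `CN(C)CCN1CCN(CC(=O)Nc2ccc(-c3nc4ccccc4o3)cc2)CC1` and compound 2 `Cc1cc(-c2nc3ccccc3o2)ccc1NC(=O)CN1CCN(CCN(C)C)CC1` share one core and differ only by a methyl in place of hydrogen on an aromatic carbon. In a functional assay on C6 cells (Rattus norvegicus) for cytotoxicity, read by MTT assay, with a stated time of 24 h (a lower number here means a stronger inhibitor, a higher number a weaker inhibitor), compound 1 gives 7010 nM, and compound 2 gives 42700 nM; between them stands a 6.1-fold higher number from compound 1 to compound 2 (0.78 log units; beyond the scatter). Among the measured compounds shown here, compound 2 therefore holds the higher of the two numbers so far, with compound 1 nearest to it. Compound 3 `Cc1cc(-c2nc3ccccc3o2)ccc1NC(=O)CN1CCN(CCCN(C)C)CC1` keeps the methyl of compound 2 and differs from it in one place: (dimethylamino)methyl in place of dimethylamino on a saturated chain carbon, two bonds along the chain from an amine nitrogen in a ring. For the measured compounds named here, no measured step bears on a change of this kind; the only step known in this assay concerns the methyl on the aromatic carbon, not the saturated chain. With nothing to point either way, the expected step from compound 2 in this assay is a 1.1-fold lower number from compound 2 to compound 3 (0.03 log units; within the scatter), meaning none beyond the scatter. Compound 3 is accordingly estimated at 40000 nM, with a range from 15000 nM to 100000 nM.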

Compound 3, half-maximal inhibitory concentration: 38700 nM
Beside the measured number, compound 3's estimate is 1.0-fold (0.01 log units) above it; the measured number falls inside the stated range.
By their numbers in this assay, from the lowest: compound 1; then compounds 3 and 2 (each within the scatter of the next).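

In this assay the change to (dimethylamino)methyl from dimethylamino, on a saturated chain carbon, two bonds along the chain from an amine nitrogen in a ring, gives a 1.1-fold lower number from compound 2 to compound 3 (0.04 log units; within the scatter) and so leaves compound 3 and compound 2 within the scatter of each other. Among the compounds shown here, this is the first reading at this position: the earlier step, a 6.1-fold higher number from compound 1 to compound 2 (0.78 log units; beyond the scatter), concerned only the methyl on an aromatic carbon, and unlike that step, this chain change does not separate the two compounds. No supporting evidence bears on this result.

Open, from the compounds shown here alone, is whether a longer chain, or a carboxylic acid in place of the dimethylamino end, would move the number at this position. Also open, going by these compounds, is whether the same chain change gives a similar step on the core of compound 1, without the aromatic methyl.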